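Chromone ether amides: tert-butyl replaced by trifluoromethoxy

A few compounds are considered here, and "the series" means these few. Any claim that something is new, unique, unknown or untested is made for them only; others in the source may bear on it.

Compound 1 `CN(C)c1ccc(C(=O)Nc2cccc(NC(=O)COc3ccc4c(c3)OCCO4)c2)cc1`: > 10000 nM
Compound 2 `CC(C)(C)c1ccc(C(=O)Nc2cccc(NC(=O)COc3ccc4c(=O)ccoc4c3)c2)cc1`: 165 nM

In an assay on isolated protein for inhibition of Rho-associated protein kinase 1 (Homo sapiens), read by scintillation counting, radiometric assay and 33P incorporation, with a stated time of 40 min, in the presence of a further agent that is not named here (on this read-out higher numbers stand for weaker inhibition and lower numbers for stronger inhibition), compound 1 gives > 10000 nM, which is a limit of the assay and not a number; it sits at the limit of > 10000 nM in this assay, at which 1 of the 2 values shown sits. Among the compounds with values here, compound 2 gives 165 nM, the only true number among the two values shown. Compound 3 `O=C(COc1ccc2c(=O)ccoc2c1)Nc1cccc(NC(=O)c2ccc(OC(F)(F)F)cc2)c1` differs from compound 2 by trifluoromethoxy in place of tert-butyl on an aromatic carbon. Within the data shown here, no measured pair shows what this change does. The step is expected to be small, a 1.5-fold higher number from compound 2 to compound 3 (0.18 log units; within the scatter), not clearly beyond the usual scatter. Compound 3 is therefore estimated at 250 nM, within a range from 80 nM to 800 nM.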

Compound 3, half-maximal inhibitory concentration: 869 nM
Estimate against measurement, compound 3: 3.5-fold (0.54 log units) below; the measured number lies above the stated range.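

Read in this assay, trifluoromethoxy in place of tert-butyl on an aromatic carbon gives a 5.3-fold higher number from compound 2 to compound 3 (0.72 log units; beyond the scatter), the first step at this position that can be read. This position therefore responds to the group it carries, and between these two groups the lower number belongs to compound 2. Nothing measured here gives a cause for this step.

The compounds shown leave open how a methyl, a chlorine or a carboxylic acid would read on this same carbon. They also leave open whether any group here would give a lower number than compound 2.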